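A Limit-Bound Start for Compound 3

The source may hold more compounds than are shown below. What is called first, only, known or untested is meant among the compounds shown, and "the series" means these compounds.

- Compound 1 `Cc1cc(N[C@H](CCCCNCc2ccc(C(F)(F)F)cc2)C(=O)NO)cc(C)c1F` gives < 3 in a physicochemical assay for lipophilicity, at pH 7.4 (a lower number here means a more polar compound, a higher number a more lipophilic compound), as a limit
- Compound 2 `Cc1cc(N[C@H](CCCCNCc2ccc(C(C)(C)C)cc2)C(=O)NO)cc(C)c1F` gives < 3 in this assay as a limit

Compound 2 has no number to start from, since its < 3 is a limit and not a measured value. The same holds across the series, where the record amounts to the limit of < 3 in this assay, at which 2 of the 2 values shown sit, and nothing firmer.

Compound 3 `Cc1cc(N[C@H](CCCCNCCCc2ccc(F)cc2)C(=O)NO)cc(C)c1F` has not yet been measured. In it, 2-(4-fluorophenyl)ethyl stands in place of 4-(tert-butyl)phenyl on a saturated chain carbon bound to an amine nitrogen 2-(4-fluorophenyl)ethyl in place of 4-(tert-butyl)phenyl on a saturated chain carbon bound to an amine nitrogen and the rest of the structure stays the same.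

Going by the values given here, only one measured step is available, a step that the two limits leave unreadable from compound 1 to compound 2 and it offers no size or direction to carry over to this change. The forecast therefore rests on the limits alone, and compound 3 is expected to stay in the same region, quite possibly as another limit. Among the compounds with values here, the expected step is a step that the limit leaves unreadable from compound 2 to compound 3 and it is a rough estimate with no measured step behind its direction. In this assay the estimate for compound 3 is 2.3 with 1.5 to 2.9 as the expected range.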

Compound 3, distribution coefficient: < 3
Compound 3: no number, only a limit; the forecaster's own chance of this, stated with the estimate: 75%; the middle value is on the limit's open side.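

In this assay, compound 3 gives < 3, which is a limit and not a number. No step can be read from compound 3 to compound 1 or compound 2, as all three carry only limits. The compounds shown leave open where any of them truly lies and whether their differing groups change the read-out at all: the limit of < 3 in this assay, at which 3 of the 3 values shown sit.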